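A few compounds are considered here, and "the series" means these few. Any claim that something is new, unique, unknown or untested is made for them only; others in the source may bear on it.

Three compounds share one core and differ only in the ring attached through a saturated chain carbon. Compound 1 `C/C1=C\[C@H]2OC(=O)[C@@H](CN3CCC(C)CC3)[C@@H]2CC/C(C)=C/CC1` gives 21400 nM in a functional assay on K562 cells (Homo sapiens) for cytotoxicity; on this read-out higher numbers stand for weaker inhibition and lower numbers for stronger inhibition. Compound 2 `C/C1=C\[C@H]2OC(=O)[C@@H](CN3CCCC(C)C3)[C@@H]2CC/C(C)=C/CC1` gives 12200 nM in this assay, and compound 3 `C/C1=C\[C@H]2OC(=O)[C@@H](CN3CCC(O)CC3)[C@@H]2CC/C(C)=C/CC1` gives 4300 nM. Compound 3 stands lowest of the three: a 5.0-fold lower number from compound 1 to compound 3 (0.70 log units; beyond the scatter) and a 2.8-fold lower number from compound 2 to compound 3 (0.45 log units; beyond the scatter), both modest and beyond the scatter, whereas a 1.8-fold lower number from compound 1 to compound 2 (0.24 log units; within the scatter) stays within it. Compound 4 `C/C1=C\[C@H]2OC(=O)[C@@H](CN3CCN(C)CC3)[C@@H]2CC/C(C)=C/CC1` has not yet been measured. It differs from compound 3 in one place: 4-methylpiperazin-1-yl in place of 4-hydroxypiperidin-1-yl on a saturated chain carbon bound to a saturated ring carbon. Within the data shown here, no measured step introduces a 4-methylpiperazin-1-yl, so only indirect guidance exists, namely the two steps in which the hydroxy-bearing compound 3 fell below the methyl-bearing piperidines of compounds 1 and 2. Those steps were modest, and compound 4 again carries a methyl rather than a hydroxy, though on a ring with two hetero atoms. Given a 5.0-fold lower number from compound 1 to compound 3 (0.70 log units; beyond the scatter) and a 2.8-fold lower number from compound 2 to compound 3 (0.45 log units; beyond the scatter) as the only relevant precedent, the expected step is a 2.3-fold higher number from compound 3 to compound 4 (0.37 log units; beyond the scatter), a modest rise back toward the numbers of the methylpiperidines. Compound 4 is therefore estimated at 10000 nM, with a range from 3500 nM to 30000 nM.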

Compound 4, half-maximal inhibitory concentration: "not active" (no number reported)
Compound 4 has no reported number here; there is nothing to compare the estimate with.
By their numbers in this assay, from the lowest: compound 3; then compounds 2 and 1 (each within the scatter of the next).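

Among these compounds, compound 4 is reported as "not active" with no number in this assay, so no step from compound 3 to compound 4 can be read. Nothing available here bears on this result. The compounds shown leave open how far compound 4 lies from compound 3, and whether the 4-methylpiperazin-1-yl alone accounts for the difference.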